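The compounds below may be only part of what the source reports. "The series", "measured", "known", "first", "only" and "open" are said of these compounds alone.

Compound 1, `COc1cccc(-c2ncnn2-c2cc(OC)c(OC)c(OC)c2)c1`: in a functional assay on MCF7 cells (Homo sapiens) for antiproliferative activity, read by MTT assay, with a stated time of 72 h (on this read-out lower numbers stand for stronger inhibition and higher numbers for weaker inhibition), compound 1 gives > 10000 nM, which is a limit of the assay and not a number.
Compound 2, `CCOc1cccc(-c2ncnn2-c2cc(OC)c(OC)c(OC)c2)c1`: compound 2 gives > 10000 nM, likewise a limit.
Compound 3, `COc1cc(-n2ncnc2-c2cccc([N+](=O)[O-])c2)cc(OC)c1OC`: compound 3 gives > 10000 nM, again a limit.

Compound 1 therefore stands only at a limit in this assay, with no measured number of its own. The steps among the measured compounds, a step that the two limits leave unreadable from compound 1 to compound 2, a step that the two limits leave unreadable from compound 1 to compound 3 and a step that the two limits leave unreadable from compound 2 to compound 3, all remain unreadable because of the limit of > 10000 nM in this assay, at which 3 of the 3 values shown sit.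

Compound 4, `COc1cc(-n2ncnc2-c2ccc(SC)cc2)cc(OC)c1OC`, differs from compound 1 in one place: 4-(methylsulfanyl)phenyl in place of 3-methoxyphenyl on an aromatic carbon. The steps from compound 1 to compound 2 and from compound 1 to compound 3 also exchange the group carried on that aromatic carbon of the shared core, so they are the ones that bear on this change, yet neither gives a readable size. With nothing readable to build on, the expectation for compound 4 is no step beyond the scatter, a step that the limit leaves unreadable from compound 1 to compound 4. Compound 4 is thus estimated at 15000 nM, within 5000 nM to 50000 nM, and is most likely to be reported again only as a limit.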

Compound 4, half-maximal inhibitory concentration: 390 nM
Beside the measured number, compound 4's estimate is 38-fold (1.59 log units) above it; measured number below the stated range.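

In this assay, going by these compounds alone, 4-(methylsulfanyl)phenyl in place of 3-methoxyphenyl on the aromatic carbon of the five-membered ring gives an at least 25-fold lower number from compound 1 to compound 4 (1.40 log units; beyond the scatter), the only step here whose size can be read. It shows that the group on this carbon can bring a compound of this series to a measured number, with the rest of the shared core unchanged. The steps among compound 1, compound 2 and compound 3 cannot be read, so they could not show this: the limit of > 10000 nM in this assay, at which 3 of the 4 values shown sit.

The change replaces the oxygen of the ether with sulfur and also moves the group from the 3-substituted to the 4-substituted phenyl, so the step cannot be assigned to either alone. From the compounds shown here alone, a 4-methoxyphenyl or a 3-(methylsulfanyl)phenyl group on the same carbon would separate the two, and how a 4-aminophenyl or a longer 4-(ethylsulfanyl)phenyl group would read remains open.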